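The source may hold more compounds than are shown below. What is called first, only, known or untested is meant among the compounds shown, and "the series" means these compounds.

Compound 1 `CCc1cc2ccccc2n(Cc2nc3ccccc3n2CCCCF)c1=O`, compound 2 `O=c1c(O)cc2ccccc2n1Cc1nc2ccccc2n1CCCCF` and the still unmeasured compound 3 `O=c1ccc2ccccc2n1Cc1nc2ccccc2n1CCCCF` share one core and differ only in what sits on a single aromatic carbon. Within the data shown here, in an ADME assay on HEp-2 cells (Homo sapiens) for cytotoxicity (on this read-out higher numbers stand for lower toxicity in this test and lower numbers for higher toxicity in this test), compound 2 gives 20200 nM, the lower of the two numbers so far, while compound 1 gives 85100 nM. The change to follow is hydrogen in place of hydroxy on an aromatic carbon, which means hydrogen in place of hydroxy on an aromatic carbon.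

Among the measured compounds shown here, only one measured step bears on this change. It is a 4.2-fold lower number from compound 1 to compound 2 (0.62 log units; beyond the scatter), a modest move beyond the scatter, made by putting hydroxy in place of ethyl on that same carbon. So far, then, the hydroxy compound has the lower number, but no measured compound shows what hydrogen does there, and a single step is thin evidence. Taking the hydroxy away may undo part of that drop, so a modest rise in this assay is expected, probably no larger than the measured step. The expected change is a 2.2-fold higher number from compound 2 to compound 3 (0.35 log units; beyond the scatter). For compound 3 the estimated value is 45000 nM, with an expected range from 15000 nM to 120000 nM.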

Compound 3, half-maximal cytotoxic concentration: 103000 nM
For compound 3 the middle estimate is 2.3-fold (0.36 log units) below the measured one, and the stated range covers the measured number.
By their numbers in this assay, from the lowest: compound 2; then compounds 1 and 3 (each within the scatter of the next).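

In this assay the hydroxy now stands out on this aromatic carbon: replacing it with hydrogen gives a 5.1-fold higher number from compound 2 to compound 3 (0.71 log units; beyond the scatter) and so cancels the earlier drop completely, rather than only in part. Hydrogen and ethyl, by contrast, cannot be told apart here, with a 1.2-fold higher number from compound 1 to compound 3 (0.08 log units; within the scatter) lying within the scatter, so an ethyl on this carbon makes no readable difference compared with the bare position. Among these three compounds, then, the lower number, which stands for higher toxicity in this test, goes with hydroxy alone, and neither of the other two compounds goes against that.

Going by these compounds, whether another group on this carbon, such as methoxy, an amine or a carboxylic acid, would also bring the number down, or a longer chain would leave it where hydrogen and ethyl sit, remains open, as does whether the same change would behave alike on a different core. No measurement on hand says why hydroxy differs from the other two groups.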